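Removing the pyridin-2-yl from compound 3

A few compounds are considered here, and "the series" means these few. Any claim that something is new, unique, unknown or untested is made for them only; others in the source may bear on it.

compound 1 `Cc1cc(C)nc(NS(=O)(=O)c2ccc(Nc3nncc4ccccc34)cc2)n1`: 0.56 nM
compound 2 `Fc1ccc(Nc2nncc3ccccc23)cc1`: 0.43 nM
compound 3 `O=S(=O)(Nc1ccccn1)c1ccc(Nc2nncc3ccccc23)cc1`: 8.4 nM

These three compounds were measured in a functional assay on SF-295 cells (Homo sapiens) for antiproliferative activity, read by sulforhodamine B assay, with a stated time of 72 h; on this read-out higher numbers stand for weaker inhibition and lower numbers for stronger inhibition. Compound 3, at 8.4 nM, has the highest number of the three. The next compound, compound 4 `NS(=O)(=O)c1ccc(Nc2nncc3ccccc23)cc1`, is related to it by hydrogen in place of pyridin-2-yl on a sulfonamide nitrogen, which is hydrogen in place of pyridin-2-yl on a sulfonamide nitrogen.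

For the measured compounds named here, only one measured step bears on this change: a 15-fold higher number from compound 1 to compound 3 (1.18 log units; beyond the scatter). That large step arose at the same sulfonamide nitrogen, so the group placed there can matter in this assay. However, it swaps one ring for another, and no measured compound carries the unsubstituted sulfonamide, so it gives size more than direction. The two other compounds lack the pyridin-2-yl and both have lower numbers: compound 1 gives 0.56 nM and compound 2 gives 0.43 nM. On that limited evidence, a move toward a lower number is expected, though it is not secure and is expected to be smaller than the measured step.

The expected change is a 3.4-fold lower number from compound 3 to compound 4 (0.53 log units; beyond the scatter). For compound 4 the estimated value is 2.5 nM, within an expected range from 0.4 nM to 15 nM.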

Compound 4, half-maximal inhibitory concentration: 5.3 nM
Estimate against measurement, compound 4: 2.1-fold (0.33 log units) below; the range from low to high includes it.
By their numbers in this assay, from the lowest: compounds 2 and 1 (each within the scatter of the next); then compounds 4 and 3 (each within the scatter of the next).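

In this assay, hydrogen and pyridin-2-yl on the sulfonamide nitrogen cannot be told apart (a 1.6-fold lower number from compound 3 to compound 4 (0.20 log units; within the scatter)), so adding this ring to the unsubstituted sulfonamide gives no measurable change. The 4,6-dimethylpyrimidin-2-yl group does stand apart, with both hydrogen (a 9.5-fold higher number from compound 1 to compound 4 (0.98 log units; beyond the scatter)) and pyridin-2-yl (a 15-fold higher number from compound 1 to compound 3 (1.18 log units; beyond the scatter)) giving higher numbers, so among these compounds the low number at this nitrogen goes with that one group and not with the presence of any ring there. The unsubstituted sulfonamide also lies well above the fluoro compound (a 12-fold higher number from compound 2 to compound 4 (1.09 log units; beyond the scatter)), which shows that a sulfamoyl group on this aromatic carbon does not by itself match fluoro in this assay.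

Nothing shown here explains why these groups differ. Going by these compounds, it remains open whether a pyrimidin-2-yl without the two methyl groups would keep the low number of compound 1, and whether a carboxylic acid or an amine in place of sulfamoyl would come closer to compound 2.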